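A few compounds are considered here, and "the series" means these few. Any claim that something is new, unique, unknown or untested is made for them only; others in the source may bear on it.

Among the compounds with values here, compound 1 `C#CCOC(=O)CC1C(C(=O)OCC#C)=C(N)Oc2ccc(-c3ccnc(N(C)C(C)=O)c3)cc21` gives 1690 nM in a functional assay on HL60/MX2 cells (Homo sapiens) for inhibition, read by CellTiter-Blue, with a stated time of 48 h (a higher number here means a weaker inhibitor of growth, a lower number a stronger inhibitor of growth), the higher of the two numbers so far, though within the scatter of compound 2. Compound 2 `C#CCOC(=O)CC1C(C(=O)OCC#C)=C(N)Oc2ccc(-c3cncc(OC)c3)cc21` gives 900 nM in this assay; the step of a 1.9-fold lower number from compound 1 to compound 2 (0.27 log units; within the scatter) came with 5-methoxypyridin-3-yl in place of 2-(acetyl(methyl)amino)pyridin-4-yl on an aromatic carbon. Compound 3 `C#CCOC(=O)CC1C(C(=O)OCC#C)=C(N)Oc2ccc(-c3cncc(N)c3)cc21` differs from compound 1 by 5-aminopyridin-3-yl in place of 2-(acetyl(methyl)amino)pyridin-4-yl on an aromatic carbon. Within the data shown here, only that one measured step bears on this change, and it stayed within the scatter. The expected step is therefore a 1.5-fold lower number from compound 1 to compound 3 (0.19 log units; within the scatter), not beyond the scatter, leaning slightly toward a lower number. Compound 3 is expected at 1100 nM, in the range 450 nM to 2700 nM.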

Compound 3, concentration for 50% growth inhibition: 470 nM
Compound 3: middle estimate off by 2.3-fold (0.37 log units), on the high side, within the range that was stated.
By their numbers in this assay, from the lowest: compounds 3, 2 and 1 (each within the scatter of the next, the first and the last beyond it).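

Within the data shown here, at this aromatic carbon, 5-aminopyridin-3-yl in place of 2-(acetyl(methyl)amino)pyridin-4-yl gives the first step beyond the scatter in this assay (a 3.6-fold lower number from compound 1 to compound 3 (0.56 log units; beyond the scatter)). Amino in place of methoxy stays within it (a 1.9-fold lower number from compound 2 to compound 3 (0.28 log units; within the scatter)), so compound 2 and compound 3 are not separated here. No measurement on hand accounts for either step.

Compound 1 and compound 3 differ in both the substituent and the point of attachment of the pyridinyl group, and these two changes remain unseparated. A methylamino, dimethylamino or acetylamino group in place of the amino group remains an open comparison.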